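Second chloro substituent on the shared core

This account rests on a few compounds, and the source may have more. Where it says the series, first, only, none or still open, it means among the compounds named here.

Compound 1 `Cn1c(N2N=C(c3ccccc3)CC2c2ccc(Cl)cc2)nc(-c2ccccc2)c(C#N)c1=O` and compound 2 `Cn1c(N2N=C(c3ccccc3)CC2c2ccccc2)nc(-c2ccc(Cl)cc2)c(C#N)c1=O` share one core and differ only in which phenyl carries the chloro. In a functional assay on MDA-MB-231 cells (Homo sapiens) for antiproliferative activity, with a stated time of 72 h (on this read-out lower numbers stand for stronger inhibition and higher numbers for weaker inhibition), compound 1 gives 28000 nM, and compound 2 gives 29100 nM. On the numbers shown, compound 2 sits with compound 1; the gap between them lies within the scatter, so both read alike. Compound 3 `Cn1c(N2N=C(c3ccccc3)CC2c2ccc(Cl)cc2)nc(-c2ccc(Cl)cc2)c(C#N)c1=O` carries both chloro groups and differs from compound 2 by chloro in place of hydrogen on an aromatic carbon. Within the data shown here, no measured step of this kind exists in the set, so no firm direction can be drawn. The step of a 1.1-fold lower number from compound 2 to compound 3 (0.03 log units; within the scatter) is expected to stay within the scatter. Compound 3 is expected to give about 27000 nM, in a range from 12000 nM to 60000 nM.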

Compound 3, half-maximal inhibitory concentration: 25100 nM
Estimate against measurement, compound 3: 1.1-fold (0.03 log units) above; measured number inside the range.
By their numbers in this assay, from the lowest: compounds 3, 1 and 2 (each within the scatter of the next).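

In this assay, phenyl to 4-chlorophenyl can now be read on two different phenyl groups of the shared core, giving a 1.2-fold lower number from compound 2 to compound 3 (0.06 log units; within the scatter) on one and a 1.1-fold lower number from compound 1 to compound 3 (0.05 log units; within the scatter) on the other. Both steps lie within the scatter, so across compound 1, compound 2 and compound 3 a second chloro reads the same as a single chloro, on either phenyl. Nothing measured on these compounds offers an explanation for this. Still open, from the compounds shown here alone, is whether an amine, a carboxylic acid or a methoxy group at these places would give a step beyond the scatter, and how the core without any chloro reads.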